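From fluoro to difluoromethoxy: an expected toxicity step

The source may report more compounds than this note shows. Statements on the series, on what has been measured and on what is new or still open speak of the compounds shown alone.

Measured in a toxicity assay on MDCK cells (Canis lupus familiaris) for cytotoxicity, read by crystal violet staining, with a stated time of 48 h; on this read-out lower numbers stand for higher toxicity in this test and higher numbers for lower toxicity in this test:
Compound 1 `Cc1ccc2[nH]c(=O)c(CN(Cc3ccc(F)cc3)Cc3ccc(C(C)(C)C)cc3)cc2c1`: > 27000 nM (a limit)
Compound 2 `CCc1ccc2[nH]c(=O)c(CN(Cc3ccc(F)cc3)Cc3ccc(C(C)(C)C)cc3)cc2c1`: > 33000 nM (a limit)
Compound 3 `CC(C)c1ccc2[nH]c(=O)c(CN(Cc3ccc(F)cc3)Cc3ccc(C(C)(C)C)cc3)cc2c1`: 7900 nM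

Compound 2 has no exact number on this scale, only a limit, > 33000 nM. The same is true of compound 1, whose limit is > 27000 nM. Compound 3 is the only one of the three with a true number, 7900 nM.

Compound 4 `CCc1ccc2[nH]c(=O)c(CN(Cc3ccc(OC(F)F)cc3)Cc3ccc(C(C)(C)C)cc3)cc2c1` departs from compound 2 at one place: difluoromethoxy in place of fluoro on an aromatic carbon. This puts difluoromethoxy in place of fluoro on an aromatic carbon.

For the measured compounds named here, no measured step touches that place, so the evidence is indirect. All three compounds differ only in the small chain on the shared core. The first step, a step that the two limits leave unreadable from compound 1 to compound 2, cannot be sized. The other two can: an at least 3.4-fold lower number from compound 1 to compound 3 (0.53 log units; beyond the scatter) and an at least 4.1-fold lower number from compound 2 to compound 3 (0.62 log units; beyond the scatter). They show that a change elsewhere in the molecule can bring a number down in this assay, though only compound 3 shows this.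

On that thin basis, the expected change is modest and towards a lower number, with a real chance of another limit. The expected step is an at least 1.8-fold lower number from compound 2 to compound 4 (0.26 log units; that floor lies within the scatter). For compound 4 the estimated value is 18000 nM, with an expected range of 6000 nM to 45000 nM.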

Compound 4, half-maximal cytotoxic concentration: > 5000 nM
Compound 4: a limit, no number; the forecaster's own chance of this, stated with the estimate: 45%; the middle value is on the limit's open side.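

In this assay, compound 4 gives only a limit, > 5000 nM. Compound 2 also gives only a limit, > 33000 nM. For the compounds shown here, no step between compound 2 and compound 4 can therefore be read. The compounds shown leave open whether difluoromethoxy in place of fluoro changes the number in this assay at all, and by how much.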